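This account rests on a few compounds, and the source may have more. Where it says the series, first, only, none or still open, it means among the compounds named here.

Compound 1, `CCCCCc1cc2cn([C@H]3C[C@H](O)[C@@H](CO)O3)c(=O)nc2o1`: in a functional assay on HEL cells (Homo sapiens) for cytotoxicity, read by microscopy (on this read-out higher numbers stand for lower toxicity in this test and lower numbers for higher toxicity in this test), compound 1 gives > 50000 nM, which is a limit of the assay.
Compound 2, `C=CCCCc1cc2cn([C@H]3C[C@H](O)[C@@H](CO)O3)c(=O)nc2o1`: compound 2 gives > 200000 nM, again a limit.
Compound 3, `C=CCCCCCCCCc1cc2cn([C@H]3C[C@H](O)[C@@H](CO)O3)c(=O)nc2o1`: compound 3 gives > 50000 nM, also a limit.

Compound 2 sits at the limit of > 200000 nM in this assay, at which 1 of the 3 values shown sits. The two other compounds sit at the limit of > 50000 nM in this assay, at which 2 of the 3 values shown sit. None of the three showed toxicity in this assay up to its tested concentration. Compound 4, `C#CCCCCc1cc2cn([C@H]3C[C@H](O)[C@@H](CO)O3)c(=O)nc2o1`, differs from compound 2 by propargyl in place of vinyl on a saturated chain carbon, three bonds along the chain from an aromatic carbon. The measured steps that bear on chain changes are a step that the two limits leave unreadable from compound 1 to compound 2, a step that the two limits leave unreadable from compound 2 to compound 3 and a step that the two limits leave unreadable from compound 1 to compound 3; all three are limits, so no size can be read from them. No change beyond the scatter is therefore expected. Compound 4 is estimated to give 150000 nM, between 50000 nM and 400000 nM. The expected step is an at least 1.3-fold lower number from compound 2 to compound 4 (0.12 log units; that floor lies within the scatter).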

Compound 4, minimum cytotoxic concentration: > 200000 nM
Compound 4 was reported as a limit; the forecaster's own chance of this, stated with the estimate: 90%; at least 1.3-fold (0.12 log units) between middle value and limit.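

Compound 4, like compound 1, compound 2 and compound 3, is reported only as a limit, so none of its steps to them can be read. The compounds shown leave open at what concentration each becomes toxic in this assay.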